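Trimethoxyphenyl naphthylmethyl ethers: dimethoxy benzyl variant

The source may hold more compounds than are shown below. What is called first, only, known or untested is meant among the compounds shown, and "the series" means these compounds.

The series shares a trimethoxyphenyl carbon bearing a naphthyl group, and is tested in a functional assay on THP-1 cells (Homo sapiens) for inhibition, read by sulforhodamine B assay, with a stated time of 48 h; on this read-out higher numbers stand for weaker inhibition and lower numbers for stronger inhibition. Compound 1 `COc1ccc(C(OCc2ccccc2)c2cccc3ccccc23)c(OC)c1OC` carries a benzyloxy on that carbon. In this assay compound 1 gives > 20000 nM, which is a limit of the assay and not a number. Of the three values recorded, compound 1 alone sits at the limit of > 20000 nM in this assay, at which 1 of the 3 values shown sits. Compound 2 `COc1ccc(C(c2ccc(OCCO)cc2)c2cccc3ccccc23)c(OC)c1OC` gives 16600 nM and compound 3 `COc1ccc(C(c2ccc(O)cc2)c2cccc3ccccc23)c(OC)c1OC` gives 9450 nM; the change from compound 1 to each gives an at least 1.2-fold lower number from compound 1 to compound 2 (0.08 log units; that floor lies within the scatter) and an at least 2.1-fold lower number from compound 1 to compound 3 (0.32 log units; beyond the scatter), while a 1.8-fold lower number from compound 2 to compound 3 (0.24 log units; within the scatter) separates the two aryl compounds.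

Compound 4 `COc1cc(COC(c2ccc(OC)c(OC)c2OC)c2cccc3ccccc23)cc(OC)c1` differs from compound 1 by 3,5-dimethoxyphenyl in place of phenyl on a saturated chain carbon bound to an oxygen on a saturated carbon. Within the data shown here, none of the measured steps touches this position: both steps from compound 1 remove the benzyloxy entirely rather than decorate it, and the step from compound 2 to compound 3 alters the aryl oxygen. Among the measured compounds shown here, no measured step therefore bears directly on the change to compound 4, and a step of no more than the scatter is expected, with the direction open. The estimated step from compound 1 to compound 4 is a number no higher from compound 1 to compound 4 (the limit leaves the size open). Compound 4 is expected to give about 20000 nM in this assay, within 6000 nM to 60000 nM, and a limit rather than a number is a likely outcome.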

Compound 4, half-maximal inhibitory concentration: > 20000 nM
Compound 4: no number, only a limit (the forecaster's own chance of this, stated with the estimate: 55%); the middle value sits exactly at the limit.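

In this assay compound 4 gives > 20000 nM, a limit of the assay and not a number. Compound 1 rests on the same limit, so no step between compound 1 and compound 4 can be read: the limit of > 20000 nM in this assay, at which 2 of the 4 values shown sit.

Left open is whether 3,5-dimethoxybenzyl in place of benzyl shifts the read-out at all, and in which direction.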